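The source may hold more compounds than are shown below. What is called first, only, known or untested is meant among the compounds shown, and "the series" means these compounds.

In a functional assay on Caco-2 cells (Homo sapiens), read by fluorescence, tested at 10 uM (on this read-out lower numbers stand for a stronger effect and higher numbers for a weaker effect at the one concentration tested), three compounds have been measured so far, all built around a chain that carries two phenol-bearing aryl groups and an amine nitrogen. Compound 1 `CCC(C)NC(=C\C(=O)/C=C/c1ccc(O)c(OC)c1)/C=C/c1ccc(O)c(OC)c1` gives 66%. Compound 2 `COc1cc(/C=C/C(=O)/C=C(/C=C/c2ccc(O)c(OC)c2)NC2CCCCC2)ccc1O` gives 63%. These two differ in one place only, (cyclohexyl in place of sec-butyl on an amine nitrogen), and the step between them is a number 3 percentage points lower from compound 1 to compound 2 (within the scatter), so the two numbers cannot be told apart. Compound 3 `CCC(C)NC(=C\C(=O)/C=C/c1ccc(O)cc1)/C=C/c1ccc(O)cc1` gives 102%, the highest number of the three and beyond the scatter from both compound 1 and compound 2, which marks it as the weakest of the measured set. The difference between the core of compound 3 and the core of compound 1 is not broken down here.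

Compound 4 `O=C(/C=C(/C=C/c1ccc(O)cc1)NC1CCCCC1)/C=C/c1ccc(O)cc1` has not yet been measured. Its change from compound 3 is cyclohexyl in place of sec-butyl on an amine nitrogen, and the place where the groups are exchanged reads word for word as it does for compound 1 and compound 2, so this is the same change seen once already. That earlier instance moved the read-out by a number 3 percentage points lower from compound 1 to compound 2 (within the scatter), a step inside the scatter. On that basis the step from compound 3 to compound 4 is expected to be about a number 3 percentage points lower from compound 3 to compound 4 (within the scatter), again small. Compound 4 is therefore estimated to give 99% in this assay, with the likely range running from 85% to 113%.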

Compound 4, a percentage reported as activity, at one concentration (the size of the read-out at that concentration, not a potency): 82%
For compound 4 the middle estimate is 17 percentage points above the measured one; the whole stated range lies above it.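

In this assay, putting cyclohexyl in place of sec-butyl on the amine nitrogen of the core of compound 3 gives a number 20 percentage points lower from compound 3 to compound 4 (beyond the scatter), and since lower numbers stand for a stronger effect here, cyclohexyl is the better of the two groups on this core. Set beside the earlier case, the same exchange does not carry over at the same size from one core to the other, and a step measured on one core was a poor guide to the step on the other: the same change on two cores in this assay, a number 3 percentage points lower (within the scatter) from compound 1 to compound 2 and a number 20 percentage points lower (beyond the scatter) from compound 3 to compound 4, 17 percentage points apart, beyond the scatter of two such steps This does not show why the two cores respond differently, nor does it give a rule for other cores, since only one pair of compounds stands behind each step and a pair shows just what happens on its own core.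

The compounds shown cover only sec-butyl and cyclohexyl on the amine nitrogen, which leaves open how an open-chain group such as n-hexyl, a ring of another size such as cyclopentyl, or an aromatic group such as benzyl would behave on either core. They also leave open which part of the difference between the two cores decides how much the exchange matters.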